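The compounds below may be only part of what the source reports. "The series", "measured", "known", "first", "only" and "open" are said of these compounds alone.

The compounds measured in a functional assay on SW480 cells (Homo sapiens) for antiproliferative activity, read by MTT assay, with a stated time of 72 h (on this read-out lower numbers stand for stronger inhibition and higher numbers for weaker inhibition), are:
compound 1 `O=c1cc(CSC(=S)N2CCCCC2)oc2cc(Cl)ccc12`, which gives 2500 nM;
compound 2 `O=c1cc(CSC(=S)N2CCCC2)oc2cc(Cl)ccc12`, which gives > 25000 nM;
compound 3 `O=c1c(CSC(=S)N2CCCCC2)coc2cc(Cl)ccc12`, which gives 790 nM.

The value for compound 2 is a limit of this assay rather than a number (the limit of > 25000 nM in this assay, at which 1 of the 3 values shown sits). Compound 1 and compound 2 differ in one place, (pyrrolidin-1-yl in place of piperidin-1-yl on a thiocarbonyl carbon), and that change gives an at least 10-fold higher number from compound 1 to compound 2 (1.00 log units; beyond the scatter).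

Compound 3 carries the same atoms as compound 1, joined differently; the difference between the two cores is not broken down here. Of the two numbers in hand, compound 3 gives the lower one, compound 1 the higher.

Compound 4 `O=c1c(CSC(=S)N2CCCC2)coc2cc(Cl)ccc12` has not yet been measured. It differs from compound 3 in one place, (pyrrolidin-1-yl in place of piperidin-1-yl on a thiocarbonyl carbon), and the place is the same word for word as the change from compound 1 to compound 2, so it is the same change made on the core of compound 3. Within the data shown here, the one time the change was measured, from compound 1 to compound 2, it gave an at least 10-fold higher number from compound 1 to compound 2 (1.00 log units; beyond the scatter), the second value sitting at the limit of this assay. Resting on that step, compound 4 is expected to show a 13-fold higher number from compound 3 to compound 4 (1.10 log units; beyond the scatter) relative to compound 3 in this assay, with a real chance that only a limit is returned. The estimate for compound 4 in this assay is 10000 nM, within a range from 3000 nM to 30000 nM.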

Compound 4, half-maximal inhibitory concentration: 7800 nM
For compound 4 the middle estimate is 1.3-fold (0.11 log units) above the measured one; the range from low to high includes it.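

In this assay, pyrrolidin-1-yl in place of piperidin-1-yl on a thiocarbonyl carbon gives a 9.9-fold higher number from compound 3 to compound 4 (0.99 log units; beyond the scatter), so the higher number seen on the first core appears again on the second, and this time as a measured step that can be read in full. Set side by side, the two steps point the same way, but their sizes cannot be compared exactly, since compound 2 gives > 25000 nM, which is a limit of the assay and not a number: the same change on two cores in this assay, an at least 10-fold higher number (1.00 log units; beyond the scatter) from compound 1 to compound 2 and a 9.9-fold higher number (0.99 log units; beyond the scatter) from compound 3 to compound 4; the limit leaves it open whether they differ
What this shows is that the direction of this one change carried from one core to the other in this pair of pairs; it does not show that the size carries over, and two cores are too few to support a rule for the series as a whole.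

The compounds shown leave open how other amines on the thiocarbonyl carbon would behave on these two cores, such as morpholin-4-yl, azepan-1-yl or an open-chain diethylamino group. They also leave open whether the same change would run the same way with the chlorine replaced by a fluorine or a methoxy group.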